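Swapping the aryl group on a urea: plasma binding

The compounds below may be only part of what the source reports. "The series", "measured", "known", "first", "only" and "open" are said of these compounds alone.

Three compounds share one core and were tested in an ADME assay on a cell-free system (plasma, Mus musculus) for protein binding. Compound 2 `CNc1nccc(N2CC[C@H](NC(=O)Nc3ccc(C)c(Cl)c3)C2)n1` gives 98.6%. Compound 1 `Nc1nccc(N2CC[C@H](NC(=O)Nc3ccc(Cl)c(C(F)(F)F)c3)C2)n1` gives 99.4%. Compound 3 `O=C(Nc1ccc(Cl)c(C(F)(F)F)c1)N[C@H]1CCN(c2ccnc(NC3CC3)n2)C1` gives 99.9%. Among these three, compound 2 has the highest unbound fraction: compound 1 comes nearest, and compound 3 stands furthest away. Going by the values given here, the one measured step that changes a single place runs a 6.0-fold lower unbound fraction from compound 1 to compound 3 (0.78 log units; beyond the scatter) and concerns the cyclopropyl group on a nitrogen on an aromatic ring, not the aryl group on the urea.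

Compound 4 `CNc1nccc(N2CC[C@H](NC(=O)Nc3cccc(OC)c3)C2)n1` differs from compound 2 at that urea end (3-methoxyphenyl in place of 3-chloro-4-methylphenyl on an amide-type nitrogen). Among the compounds with values here, no measured pair here alters the aryl group on the amide-type nitrogen, so the step from compound 1 to compound 3 does not bear on this change, and the expectation must be held loosely. The replacement exchanges a chlorine and a methyl for a methoxy group, which brings in one hydrogen-bond acceptor. A modest move toward a higher unbound fraction is expected, a 2.5-fold higher unbound fraction from compound 2 to compound 4 (0.40 log units; beyond the scatter). In this assay compound 4 is thus estimated at 96.5%, with a likely range from 93% to 98.5%.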

Compound 4, plasma protein binding: 91.6%
Compound 4: middle estimate off by 2.4-fold (0.38 log units) (unbound fraction), on the low side, and the stated range ends above it.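

Going by these compounds alone, until now, the only step that changed a single place concerned the cyclopropyl group on a nitrogen on an aromatic ring, so nothing showed whether the aryl group on the amide-type nitrogen mattered for binding in this assay. The new step, a 6.0-fold higher unbound fraction from compound 2 to compound 4 (0.78 log units; beyond the scatter), shows that it does, and its size matches that of the earlier step, a 6.0-fold lower unbound fraction from compound 1 to compound 3 (0.78 log units; beyond the scatter), though it runs toward more free compound rather than less. The two aryl groups both count 8 heavy atoms and one six-membered aromatic ring, yet this exchange of 3-chloro-4-methylphenyl for 3-methoxyphenyl still shifts the unbound fraction beyond the scatter, and no measurement at hand explains the shift.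

The chlorine and the methyl leave together as the methoxy group enters, so this single step cannot show how much of the shift belongs to each of the three groups, and a plain phenyl group would be a useful point of comparison. It also leaves open how binding would respond to an aryl group carrying an amine or a carboxylic acid, and whether the same aryl exchange would act alike with a cyclopropyl group on the other nitrogen.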